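The source may report more compounds than this note shows. Statements on the series, on what has been measured and on what is new or still open speak of the compounds shown alone.

Working notes on the series, values in a physicochemical assay for lipophilicity, at pH 7.4; on this read-out lower numbers stand for lower lipophilicity and higher numbers for higher lipophilicity:

- compound 1 `CCc1ccc(N(CC(C)C)S(=O)(=O)c2ccc3c(c2)C(O)CC(C2CCOCC2)O3)cc1` gives 4.12
- compound 2 `CC(C)CN(c1cccc(F)c1)S(=O)(=O)c1ccc2c(c1)C(O)CC(C1CCOCC1)O2` gives 3.39
- compound 3 `CC(C)CN(Cc1ccccc1C(F)(F)F)S(=O)(=O)c1ccc2c(c1)C(O)CC(C1CCOCC1)O2` gives 4.23

Compound 3 cannot be separated from compound 1 on these numbers (a number 0.11 log units higher from compound 1 to compound 3 (within the scatter)). It does stand clear of compound 2 (a number 0.84 log units higher from compound 2 to compound 3 (beyond the scatter)).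

The next compound is compound 4 `CC(C)CN(c1ccc(N(C)C)cc1)S(=O)(=O)c1ccc2c(c1)C(O)CC(C1CCOCC1)O2`, with 4-(dimethylamino)phenyl in place of 2-(trifluoromethyl)benzyl on a sulfonamide nitrogen.

Compound 4 thus carries a substituted phenyl at this place, like compound 1 with 4-ethylphenyl and compound 2 with 3-fluorophenyl. The same two steps from those compounds to compound 3 therefore bear on it, one within the scatter and one beyond it. The step between the two phenyl compounds also bears on it (a number 0.73 log units lower from compound 1 to compound 2 (beyond the scatter)), as it shows that the choice of phenyl group alone can move the number beyond the scatter. Going by the values given here, no measured compound carries the dimethylamino group, so its own contribution is unknown.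

A value inside the span set by compound 2 at 3.39 and compound 1 at 4.12 is expected, nearer the lower end. The expected change is a modest fall in this assay (a number 0.63 log units lower from compound 3 to compound 4 (beyond the scatter)). Compound 4 is estimated at 3.6 (expected range 3.1 to 4.1).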

Compound 4, distribution coefficient: 3.51
Compound 4: middle estimate off by 0.09 log units, on the high side, within the range that was stated.
By their numbers in this assay, from the lowest: compounds 2 and 4 (each within the scatter of the next); then compounds 1 and 3 (each within the scatter of the next).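

In this assay, the step at the aromatic carbon, with dimethylamino in place of ethyl, gives a number 0.61 log units lower from compound 1 to compound 4 (beyond the scatter), so exchanging this one substituent on the phenyl ring is enough to separate two compounds that otherwise match. The phenyl compounds do not share one level on the sulfonamide nitrogen: 4-(dimethylamino)phenyl cannot be told from 3-fluorophenyl (a number 0.12 log units higher from compound 2 to compound 4 (within the scatter)), yet it stands clear of 2-(trifluoromethyl)benzyl (a number 0.72 log units lower from compound 3 to compound 4 (beyond the scatter)), whereas compound 1, also a phenyl compound, could not be separated from that benzyl compound, so a phenyl group at this place does not by itself set the number. Nothing available explains these differences.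

The compounds shown include no unsubstituted phenyl on the sulfonamide nitrogen, so the substituents cannot yet be set against a plain ring. From the compounds shown here alone, it also remains open how a plain benzyl would compare with 2-(trifluoromethyl)benzyl, and whether a carboxylic acid or a longer chain in place of the ethyl would move the number further from that of compound 1.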